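Propyl Gives Way to Cyano: Expected Solubility Shift

A few compounds are considered here, and "the series" means these few. Any claim that something is new, unique, unknown or untested is made for them only; others in the source may bear on it.

Measured so far:
compound 1, `CCc1ccc(-c2nc3c(c(C)nn3-c3ccccc3)c(-c3ccccc3F)c2C#N)cc1`: 1700 nM
compound 2, `CCCc1ccc(-c2nc3c(c(C)nn3-c3ccccc3)c(-c3ccccc3O)c2C#N)cc1`: 6500 nM

Both compounds were tested in a physicochemical assay for solubility, read by spectrophotometry, in phosphate buffer, with a stated time of 18 h, at pH 7.4; on this read-out lower numbers stand for lower solubility and higher numbers for higher solubility. In this assay compound 1 gives 1700 nM, and compound 2 gives 6500 nM. Compound 2 thus stands with the higher of the two numbers, and the gap to compound 1 lies beyond the usual scatter of such measurements, so the two values are genuinely different rather than noise around a common level.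

The next compound, compound 3, `Cc1nn(-c2ccccc2)c2nc(-c3ccc(C#N)cc3)c(C#N)c(-c3ccccc3O)c12`, keeps the shared core of compound 2 and changes one group: cyano in place of propyl on an aromatic carbon. Among the measured compounds shown here, since no measured pair differs in exactly this way, there is no measured step to lean on; the expectation must rest on the change itself.

Compound 3 is expected to move to a higher number in this assay, with a step of a 2.8-fold higher number from compound 2 to compound 3 (0.44 log units; beyond the scatter) that is expected to be larger than the scatter. Compound 3 is therefore estimated at 18000 nM, with a likely range from 6000 nM to 50000 nM.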

Compound 3, solubility: 1700 nM
Estimate against measurement, compound 3: 11-fold (1.02 log units) above; the whole stated range lies above it.
By their numbers in this assay, from the lowest: compounds 1 and 3 (each within the scatter of the next); then compound 2.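

In this assay, cyano in place of propyl on an aromatic carbon, para to a large group, gives a 3.8-fold lower number from compound 2 to compound 3 (0.58 log units; beyond the scatter), so what sits at this position matters to the read-out. Among the compounds shown here, this is the first comparison here between two compounds that differ in only one place, and it shows that going from 4-propylphenyl to 4-cyanophenyl, which removes a chain and brings in a nitrile with a hydrogen-bond acceptor, moves the number down rather than up. No measurement shown here gives a reason for this step, so it stands as an observation without an explanation.

The compounds shown leave open how other groups at this position would read, such as an amine, a carboxylic acid or a longer chain like butyl, and whether those numbers would fall into any order. They also leave open whether the same change would give a step of similar direction and size in a compound carrying a different group elsewhere on the shared core.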